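The source may hold more compounds than are shown below. What is called first, only, known or untested is meant among the compounds shown, and "the series" means these compounds.

Working notes on the series. In an ADME assay on HEK293 cells (Homo sapiens) for cytotoxicity, read by CellTiter-Glo, with a stated time of 72 h (a higher number here means that more compound is needed for the effect, a lower number that less compound is needed), compound 1 (`C[C@@H]1CC[C@H]2CC3C(=O)CC[C@@]31C2(C)C`) gives 26000 nM and compound 2 (`CCOC(=O)CNC(=O)[C@H](CS[C@H]1[C@@H]2C(=O)/C(C)=C\C3=C[C@H](C)C[C@@]34O[C@]2(CC1(C)C)[C@@H](C)C4=O)NC(=O)CC[C@H](N)C(=O)O`) gives 26000 nM while compound 3 (`CC1=C2CC(C)(C)/C=C/C/C(C)=C\C3=C[C@H](C)C[C@]3(O2)C1=O`) gives 26000 nM as well, so compound 3 stands level with both. Compound 4 (`CC(=O)O[C@H]1/C=C/C(C)(C)CC2=C(C)C(=O)[C@]3(C[C@@H](C)C=C3/C=C\1C)O2`) differs from compound 3 by acetoxy in place of hydrogen on a saturated ring carbon and has no value yet. Going by the values given here, no measured pair differs in one place, so the data show no step of this kind. With compound 3 at 26000 nM as the only close reference, the expected change is no change at the digits printed from compound 3 to compound 4 (within the scatter) in this assay with none beyond the scatter foreseen. Compound 4 is estimated at 26000 nM within an expected range from 12000 nM to 40000 nM for now.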

Compound 4, half-maximal effective concentration: 26000 nM
Beside the measured number, compound 4's estimate shows no gap at the digits printed; measured number inside the range.
By their numbers in this assay, from the lowest: compounds 1, 2, 3 and 4 (each within the scatter of the next).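

In this assay the series now has its first step between compounds that differ in one place: acetoxy in place of hydrogen on a saturated ring carbon gives no change at the digits printed from compound 3 to compound 4 (within the scatter) in this read-out. This carbon, next to the ring atom that bears a methyl group, thus carries acetoxy with no shift beyond the scatter. From the compounds shown here alone, whether a hydroxyl, an amine or a longer ester chain on the same carbon would read alike remains open. No measurement at hand speaks to the reason for this result.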